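The compounds below may be only part of what the source reports. "The series", "measured", "known", "first", "only" and "open" are said of these compounds alone.

Compound 2, whose structure is `Cn1c(=O)c(S(=O)(=O)c2ccc(F)cc2F)cc2cnc(Nc3ccncn3)nc21`, gives 30000 nM in a functional assay on K562 cells (Homo sapiens) for inhibition, read by trypan blue exclusion, with a stated time of 72 h (a lower number here means a stronger inhibitor, a higher number a weaker inhibitor), the highest number among the two measured compounds. Its nearest neighbour is compound 1, `Cn1c(=O)c(S(=O)(=O)Cc2ccc(F)cc2F)cc2cnc(Nc3ccc4[nH]ccc4c3)nc21`, which gives 1000 nM in this assay; the gap between the two lies beyond the scatter, so compound 2 is the weaker inhibitor of the pair. Going by the values given here, compound 1 and compound 2 differ in more than one place, so no single step between them can be read from these two values.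

Compound 3, `Cc1cc2cc(Nc3ncc4cc(S(=O)(=O)c5ccc(F)cc5F)c(=O)n(C)c4n3)ccc2[nH]1`, is compound 2 with 2-methyl-1H-indol-5-yl in place of pyrimidin-4-yl on a nitrogen on an aromatic ring. Among the compounds with values here, the group that enters is close to the one that compound 1 carries at the same place, and compound 1 has the lower number of the two measured compounds, so a move toward stronger inhibition is expected. Because compound 1 gives 1000 nM, the number for compound 3 is expected to fall well below that of compound 2, with a step of about a 20-fold lower number from compound 2 to compound 3 (1.30 log units; beyond the scatter). Compound 3 is therefore estimated at 1500 nM in this assay, within a range from 300 nM to 8000 nM.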

Compound 3, half-maximal inhibitory concentration: 750 nM
The estimate for compound 3 lay 2.0-fold (0.30 log units) above the measured number, and the stated range covers the measured number.
By their numbers in this assay, from the lowest: compounds 3 and 1 (each within the scatter of the next); then compound 2.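

In this assay, going by these compounds alone, the exchange of (pyrimidin-4-yl)amino for (2-methyl-1H-indol-5-yl)amino gives the first reading of a single change at this place, a 40-fold lower number from compound 2 to compound 3 (1.60 log units; beyond the scatter), a large step beyond the scatter, so the number here depends strongly on the group carried on this nitrogen while the rest of the molecule stays fixed. Within the data shown here, the step also brings the series back to the level of compound 1: compound 3 gives 750 nM and compound 1 gives 1000 nM, values within the scatter of each other, although the two compounds differ in more than one place and no step between them can be read. Nothing shown here explains why the change has an effect of this size.

The compounds shown do not separate the part played by the 2-methyl group from that of the indole rings themselves, and an unsubstituted 1H-indol-5-yl would be needed to tell them apart. From the compounds shown here alone, it also remains open how a plain phenyl ring or a morpholine-bearing phenyl ring would read at this place.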